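The compounds below may be only part of what the source reports. "The series", "measured", "known", "first", "only" and "open" are said of these compounds alone.

Compound 1 `Nc1ccc(S(=O)(=O)N2CCN(c3ncc(C(O)(C(F)(F)F)C(F)(F)F)cc3Br)CC2)cn1`: < 14 mL.min-1.g-1
Compound 2 `Nc1ccc(S(=O)(=O)N2CCN(c3ncc(C(O)(C(F)(F)F)C(F)(F)F)cc3-c3ccc4sccc4c3)CC2)cn1`: 48 mL.min-1.g-1

In an ADME assay (liver) for metabolic stability, with Liver microsome (Homo sapiens) as the target, using microsomes and NADPH, with a stated time of 30 min, tested at 1 uM (on this read-out higher numbers stand for fast clearance and lower numbers for slow clearance), compound 1 gives < 14 mL.min-1.g-1, and this value is a limit of the assay, not a number. Among the compounds with values here, compound 2 gives 48 mL.min-1.g-1, the only actual number so far. The next analogue, compound 3 `Nc1ccc(S(=O)(=O)N2CCN(c3ncc(C(O)(C(F)(F)F)C(F)(F)F)cc3-c3cc4ccccc4[nH]3)CC2)cn1`, keeps the shared core and exchanges one group: 1H-indol-2-yl in place of 1-benzothiophen-5-yl on an aromatic carbon. Within the data shown here, only one measured step bears on this place, an at least 3.4-fold higher number from compound 1 to compound 2 (0.53 log units; beyond the scatter), and it lies beyond the scatter. That step put 1-benzothiophen-5-yl in place of bromo, a far larger exchange than swapping one group with a five-membered and a six-membered aromatic ring for another of the same kind. Among the measured compounds shown here, no measured step covers such a swap, so the guide is indirect and the range must stay wide. A shift as large as the measured one is not expected in this assay, and the expected change is a 1.2-fold lower number from compound 2 to compound 3 (0.08 log units; within the scatter), which would lie within the scatter. For compound 3 the estimate is 40 mL.min-1.g-1, with an expected range from 16 mL.min-1.g-1 to 95 mL.min-1.g-1.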

Compound 3, intrinsic clearance in microsomes: < 14 mL.min-1.g-1
Compound 3 gave a limit, no number; the forecaster's own chance of this, stated with the estimate: 12%; middle value at least 2.8-fold (0.45 log units) away from the limit.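

The earlier compounds shown here showed only that 1-benzothiophen-5-yl at this place, on an aromatic carbon ortho to a large group, gives a higher number than bromo, whereas exchanging it for 1H-indol-2-yl, with the same ring types, gives an at least 3.4-fold lower number from compound 2 to compound 3 (0.53 log units; beyond the scatter). In this assay compound 3 gives < 14 mL.min-1.g-1, which is a limit and not a number. A group with a five-membered and a six-membered aromatic ring at this place therefore does not by itself lead to the higher number, and compound 2 alone stands clear of the limit: the limit of < 14 mL.min-1.g-1 in this assay, at which 2 of the 3 values shown sit.

As far as these compounds go, the step between compound 1 and compound 3 cannot be read, as both values are limits, so the order of bromo and 1H-indol-2-yl stays unknown. Also open, from the compounds shown here alone, is whether the difference follows the nitrogen with its hydrogen-bond donor that enters, the sulfur that leaves or the changed point of attachment, and what an amine, a carboxylic acid or a longer chain would give at this place.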